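Adding a Methoxy Group to the Core of Compound 1

The source may report more compounds than this note shows. Statements on the series, on what has been measured and on what is new or still open speak of the compounds shown alone.

Measured so far:
compound 1, `COc1cc(/C=C/C(=O)c2ccccc2F)cc(OC)c1OC`: 228 nM
compound 2, `COc1ccc(/C=C/C(=O)c2ccccc2F)c(OC)c1`: 175 nM
compound 3, `COc1cc(OC)c(OC)cc1/C=C/C(=O)c1ccccc1F`: 293 nM

All three numbers come from a functional assay on HeLa cells (Homo sapiens) for cytotoxicity, read by MTT assay, with a stated time of 72 h (on this read-out lower numbers stand for stronger inhibition and higher numbers for weaker inhibition), and all three lie within the usual scatter of one another, so none of them can be set apart as the more or less potent compound. Compound 2 and compound 1 carry differently substituted cores; the difference between the two cores is not broken down here. Compound 3 differs from compound 2 by methoxy in place of hydrogen on an aromatic carbon, and that change gave a 1.7-fold higher number from compound 2 to compound 3 (0.22 log units; within the scatter).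

Compound 4, `COc1ccc(C(=O)/C=C/c2cc(OC)c(OC)c(OC)c2)c(F)c1`, has not yet been measured. It differs from compound 1 by methoxy in place of hydrogen on an aromatic carbon. Among the compounds with values here, this is the same kind of change as the one from compound 2 to compound 3, but its surroundings differ: in compound 3 the entering methoxy sits ortho to a methoxy group, meta to a large group and para to a methoxy group, whereas in compound 4 it sits meta to a fluoro group and para to a large group.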

Compound 4, half-maximal inhibitory concentration: 144 nM
Compound 4: middle estimate off by 2.1-fold (0.32 log units), on the high side; low and high end bracket the measured number.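

In this assay, methoxy in place of hydrogen on an aromatic carbon gave a 1.6-fold lower number from compound 1 to compound 4 (0.20 log units; within the scatter), so on this core the step cannot be told apart from no change at all. The same change on two cores gave steps that do not differ from each other by more than the measurements can resolve: the same change on two cores in this assay, a 1.7-fold higher number (0.22 log units; within the scatter) from compound 2 to compound 3 and a 1.6-fold lower number (0.20 log units; within the scatter) from compound 1 to compound 4, 2.7-fold (0.42 log units) apart, within the scatter of two such steps

This gives no sign that the core alters what the change does, but it does not prove that the change carries over from one core to another, since both steps are small and in compound 4 the methoxy sits meta to a fluoro group and para to a large group, surroundings that compound 3 does not share.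

The compounds shown leave open whether another group in that same place, such as an amine, a carboxylic acid or a longer chain like ethoxy, would shift the number beyond the scatter. They also leave open whether methoxy in place of hydrogen would give a clear step on any other core.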